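Changing the group at one position of the shared core

A few compounds are considered here, and "the series" means these few. Any claim that something is new, unique, unknown or untested is made for them only; others in the source may bear on it.

For the measured compounds named here, compound 2 `CC(=O)c1ccc(NC(=O)N2CCN(c3ccnc(Nc4ccc(N5CCC(C)CC5)cc4)n3)CC2)cc1` gives 26400 nM in a functional assay on HEL cells (Homo sapiens) for inhibition, read by CCK-8 assay, with a stated time of 72 h (a lower number here means a stronger inhibitor of growth, a higher number a weaker inhibitor of growth), the highest of the two numbers so far; compound 1 `CC(=O)c1ccc(NC(=O)N2CCN(c3ccnc(Nc4ccc(N5CCN(C)CC5)cc4)n3)CC2)cc1` gives 14100 nM, within the scatter of that. Going by the values given here, the only measured step, a 1.9-fold higher number from compound 1 to compound 2 (0.27 log units; within the scatter), stayed within the scatter. Compound 3 `CC(=O)c1ccc(NC(=O)N2CCN(c3ccnc(Nc4ccc(OCCCN5CCCC5)cc4)n3)CC2)cc1` differs from compound 2 by 3-(pyrrolidin-1-yl)propoxy in place of 4-methylpiperidin-1-yl on an aromatic carbon. The earlier step altered the same place and barely moved the number, so no shift beyond the scatter is expected in this assay. Compound 3 is therefore estimated at 15000 nM, with a range from 5000 nM to 50000 nM. The expected step is a 1.8-fold lower number from compound 2 to compound 3 (0.25 log units; within the scatter).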

Compound 3, concentration for 50% growth inhibition: 3300 nM
For compound 3 the middle estimate is 4.5-fold (0.66 log units) above the measured one, outside the stated range (below it).
By their numbers in this assay, from the lowest: compound 3; then compounds 1 and 2 (each within the scatter of the next).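

This position is not indifferent to its group: 3-(pyrrolidin-1-yl)propoxy in place of 4-methylpiperidin-1-yl gives an 8.0-fold lower number from compound 2 to compound 3 (0.90 log units; beyond the scatter) and in place of 4-methylpiperazin-1-yl gives a 4.3-fold lower number from compound 1 to compound 3 (0.63 log units; beyond the scatter) in this assay at this aromatic carbon. The swap between the two six-membered rings had shown no such shift. Nothing measured here says why the number fell.

As far as these compounds go, the new group differs in its oxygen, chain and ring all at once, so the part that matters remains open. A plain propoxy chain without the amine, or a longer chain ending in the same pyrrolidine, would help separate these parts.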